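Sulfonyl ring swaps and human microsomal clearance

The source may report more compounds than this note shows. Statements on the series, on what has been measured and on what is new or still open speak of the compounds shown alone.

Measured so far:
compound 1 `O=C(NCc1ccc(S(=O)(=O)C2CCC(F)(F)CC2)cc1)N1Cc2ccncc2C1`: 6 mL/min/kg
compound 2 `CCC(=O)N1CCC(S(=O)(=O)c2ccc(CNC(=O)N3Cc4ccncc4C3)cc2)CC1`: 11 mL/min/kg

In an ADME assay on microsomes from liver (Homo sapiens) for pharmacokinetics, read by LC-MS, with a stated time of 60 min, tested at 1 uM (a lower number here means slower removal, a higher number faster removal of the compound), compound 1 gives 6 mL/min/kg and compound 2 gives 11 mL/min/kg. For the measured compounds named here, compound 2 sits at one end of the two numbers, but the single step between them, a 1.8-fold higher number from compound 1 to compound 2 (0.26 log units; within the scatter), lies within the scatter, so the two compounds are not separated by this measurement.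

Compound 3 `O=C(NCc1ccc(S(=O)(=O)N2CCC(O)CC2)cc1)N1Cc2ccncc2C1` is the next member, not yet tested. It differs from compound 2 as follows: 4-hydroxypiperidin-1-yl in place of 1-propanoylpiperidin-4-yl on a sulfonyl sulfur. Going by the values given here, the only step that bears on this change is the earlier swap at the same sulfonyl sulfur, a 1.8-fold higher number from compound 1 to compound 2 (0.26 log units; within the scatter), which stayed within the scatter; the shared core and the rest of the molecule are unchanged. Among the compounds with values here, with a single small step as the only guide, no movement beyond the scatter is expected in this assay, and the direction cannot be called. Compound 3 is therefore estimated at 9 mL/min/kg, with a range of 4.5 mL/min/kg to 18 mL/min/kg. This estimate means a step of a 1.2-fold lower number from compound 2 to compound 3 (0.09 log units; within the scatter).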

Compound 3, clearance: 6 mL/min/kg
Compound 3: the middle estimate sits 1.5-fold (0.18 log units) above what was measured, within the range that was stated.
By their numbers in this assay, from the lowest: compounds 1, 3 and 2 (each within the scatter of the next).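

Working notes on the sulfonyl sulfur: in this assay, the swap to 4-hydroxypiperidin-1-yl gives a 1.8-fold lower number from compound 2 to compound 3 (0.26 log units; within the scatter), and the comparison with the 4,4-difluorocyclohexyl compound gives no change at the digits printed from compound 1 to compound 3 (within the scatter). All three groups tested at this place therefore give values within the scatter of one another, even though 4-hydroxypiperidin-1-yl is smaller than 1-propanoylpiperidin-4-yl by heavy-atom count, loses the double bond outside aromatic rings and brings a hydrogen-bond donor. No supporting data are available to explain why the values stay so close.

From the compounds shown here alone, whether an amine, a carboxylic acid or a longer chain on the sulfonyl sulfur would move the number beyond the scatter remains open. Going by these compounds, compounds 1, 2 and 3 all keep the shared core and differ only at this place, so the response of this read-out to a change anywhere else in the molecule also remains open.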